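Capping a free hydroxy of compound 1 with methyl

The compounds below may be only part of what the source reports. "The series", "measured", "known", "first", "only" and "open" are said of these compounds alone.

In a functional assay on M14 cells (Homo sapiens) for cytotoxicity, read by sulforhodamine B assay, with a stated time of 48 h (on this read-out lower numbers stand for stronger inhibition of growth and higher numbers for weaker inhibition of growth), compound 1 (`COc1cc(C(=O)c2ccc(OC)c(O)c2OC)cc(OC)c1O`) gives 455 nM, and compound 2 (`COc1cc(C(=O)c2ccc3c(c2)oc(=O)n3S(C)(=O)=O)cc(OC)c1OC`) gives 1360 nM. Compound 1 therefore holds the lower number of the two, and the gap lies beyond the usual scatter. For the measured compounds named here, these two compounds differ in more than one place, so no measured single-place step is available as a guide.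

Compound 3 (`COc1ccc(C(=O)c2cc(OC)c(OC)c(OC)c2)c(OC)c1O`) has not yet been measured in this assay. It departs from compound 1 by methyl in place of hydrogen on an oxygen on an aromatic ring, or hydroxy to methoxy. A moderate step towards stronger growth inhibition is expected, with the estimated change being a 3.0-fold lower number from compound 1 to compound 3 (0.48 log units; beyond the scatter). Going by the values given here, no measured pair shows this change, so the range is kept wide. For compound 3 the expected value is 150 nM, with an estimated range of 40 nM to 600 nM.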

Compound 3, concentration for 50% growth inhibition: < 10 nM
Compound 3 was reported as a limit; the forecaster's own chance of this, stated with the estimate: 3%; middle value at least 15-fold (1.17 log units) from the limit.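

Hydroxy to methoxy at this position gives an at least 45-fold lower number from compound 1 to compound 3 (1.65 log units; beyond the scatter) in this assay, the first single-place step in the series. A free hydroxy here is therefore not needed for growth inhibition in this assay, and capping it with methyl is a large change rather than a minor adjustment. Compound 3 is reported only as a limit, not as a number: the limit of < 10 nM in this assay, at which 1 of the 3 values shown sits.

As far as these compounds go, it remains open whether this gain is specific to methyl or would also appear with an ethyl group or a longer chain on this oxygen, or with an amine in place of the hydroxy. Also open, from the compounds shown here alone, is how the number would respond to capping or replacing the other free hydroxy, which compound 3 keeps.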